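Methyl to Trifluoromethyl, Repeated on a Second Core

The source may report more compounds than this note shows. Statements on the series, on what has been measured and on what is new or still open speak of the compounds shown alone.

Compound 1 `COC(=O)C1=C(C)N=C(C)/C(=C(/O)OC)C1c1cccc(N/C(=N/CCNC2CCN(c3ccccc3C)CC2)NC#N)c1` and compound 2 `COC(=O)C1=C(C)N=C(C)/C(=C(/O)OC)C1c1cccc(N/C(=N/CCNC2CCN(c3ccccc3C(F)(F)F)CC2)NC#N)c1` share one core, while compound 3 `COC(=O)C1=C(C)N=C(C)/C(=C(/O)OC)C1c1cccc(NC(=O)NCCNC2CCN(c3ccccc3C)CC2)c1` and compound 4 `COC(=O)C1=C(C)N=C(C)/C(=C(/O)OC)C1c1cccc(NC(=O)NCCNC2CCN(c3ccccc3C(F)(F)F)CC2)c1` share another; the difference between the two cores is not broken down here. In an assay on SK-N-MC cells for inhibition of Neuropeptide Y receptor type 1 (Homo sapiens) (a lower number here means a stronger inhibitor, a higher number a weaker inhibitor), compound 1 gives 4 nM and compound 2 gives 14 nM. The change between them, (trifluoromethyl in place of methyl on an aromatic carbon), brought a 3.5-fold higher number from compound 1 to compound 2 (0.54 log units; beyond the scatter). In this assay compound 3 gives 4 nM, level with compound 1 at the digits given. Compound 4 carries the same change, (trifluoromethyl in place of methyl on an aromatic carbon), made on the core of compound 3. Because the same change on the core of compound 1 brought a 3.5-fold higher number from compound 1 to compound 2 (0.54 log units; beyond the scatter), a step of similar size is expected here, so that compound 4 is expected to show a 3.5-fold higher number from compound 3 to compound 4 (0.54 log units; beyond the scatter). Compound 4 is thus estimated at 14 nM in this assay, most likely between 6 nM and 35 nM.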

Compound 4, half-maximal inhibitory concentration: 31 nM
Compound 4: middle estimate off by 2.2-fold (0.35 log units), on the low side, within the range that was stated.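

In this assay, the change from methyl to trifluoromethyl on the core of compound 3 brought a 7.8-fold higher number from compound 3 to compound 4 (0.89 log units; beyond the scatter) and so raised the number on this core too. The rise therefore appears on both cores, and the two steps cannot be told apart in size: the same change on two cores in this assay, a 3.5-fold higher number (0.54 log units; beyond the scatter) from compound 1 to compound 2 and a 7.8-fold higher number (0.89 log units; beyond the scatter) from compound 3 to compound 4, 2.2-fold (0.35 log units) apart, within the scatter of two such steps. For the compounds shown here, this supports carrying the change between these two cores, but it rests on only two pairs of compounds, so it does not show that the change would behave alike on other cores, nor why the number rises.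

On these data alone, what a chlorine, a methoxy group or a plain hydrogen in the same place would do on either core remains open. Also open, as far as these compounds go, is whether a core with a different linking group would show a similar step.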